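A few compounds are considered here, and "the series" means these few. Any claim that something is new, unique, unknown or untested is made for them only; others in the source may bear on it.

Measured compounds, all in an assay on isolated protein for inhibition of Leucine-rich repeat serine/threonine-protein kinase 2 (Homo sapiens), read by fluorescence, with a stated time of 60 min; a lower number here means a stronger inhibitor, a higher number a weaker inhibitor:

compound 1, `COc1ccc2c(c1)/C(=C/c1cc3c([nH]1)CCN(C(=O)N1CCN(C)CC1)C3)C(=O)N2`, gives 9 nM
compound 2, `COc1ccc2c(c1)/C(=C/c1[nH]c3c(c1Cl)CN(C(C)=O)CC3)C(=O)N2`, gives 8 nM
compound 3, `CC(=O)N1CCc2[nH]c(/C=C3\C(=O)Nc4ccc(C(F)(F)F)cc43)cc2C1`, gives 31 nM

Compound 3 gives the highest number of the three in this assay. Compound 1 and compound 2 both sit lower by margins beyond the usual scatter, so compound 3 is the weakest inhibitor of the set; compound 1 and compound 2 lie within the scatter of each other and are not ordered.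

Compound 4, `CC(=O)N1CCc2[nH]c(/C=C3\C(=O)Nc4ccc([N+](=O)[O-])cc43)cc2C1`, is not yet measured. It differs from compound 3 in one place: nitro in place of trifluoromethyl on an aromatic carbon. Within the data shown here, no pair of measured compounds shows this change, so no measured step guides the size of the effect. Compound 1 carries a methoxy at the same place and gives a lower number than compound 3, but that is a different group and a different saturated ring elsewhere in the molecule, so it does not fix the direction here.

The expected step in this assay from compound 3 to compound 4 is a 1.2-fold lower number from compound 3 to compound 4 (0.09 log units; within the scatter), small and within the scatter. Compound 4 is expected to give about 25 nM in this assay, estimated between 8 nM and 80 nM.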

Compound 4, half-maximal inhibitory concentration: < 3 nM
Compound 4: a limit, no number (the forecaster's own chance of this, stated with the estimate: 3%); at least 8.3-fold (0.92 log units) between middle value and limit.
By their numbers in this assay, from the lowest: compounds 2 and 1 (each within the scatter of the next); then compound 3. At a limit, below all of these: compound 4.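

In this assay, this aromatic carbon of the shared core proves sensitive to the group it carries: with the rest of the molecule unchanged, nitro in place of trifluoromethyl gives an at least 10-fold lower number from compound 3 to compound 4 (1.01 log units; beyond the scatter). Compound 4 gives < 3 nM, which is a limit of the assay and not a number. The full size of the step cannot be read from this result: the limit of < 3 nM in this assay, at which 1 of the 4 values shown sits.

Going by these compounds, this change appears in a single pair, so whether it carries over to the core of compound 1 or the core of compound 2 remains open. On these data alone, how a nitrile, an amine or a carboxylic acid on this aromatic carbon would compare with nitro also remains open.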